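Series notes: compound 2 to compound 3

The source may hold more compounds than are shown below. What is called first, only, known or untested is meant among the compounds shown, and "the series" means these compounds.

Measured so far in an in vitro ADME assay on microsomes from liver (Homo sapiens) for pharmacokinetics; on this read-out lower numbers stand for slow clearance and higher numbers for fast clearance
- compound 1 `O=C(N[C@@H](CCN1C[C@@H]2CN(C(=O)c3ccccn3)C[C@@H]2C1)c1cccc(F)c1)C1CCOC1` gives 55 mL.min-1.g-1
- compound 2 `O=C(N[C@@H](CCN1C[C@@H]2CN(C(=O)c3ccc(C(F)F)cn3)C[C@@H]2C1)c1cccc(F)c1)C1CCOC1` gives 253 mL.min-1.g-1

Compound 2 (253 mL.min-1.g-1) holds the higher of the two numbers. Within the data shown here, the one measured step is a 4.6-fold higher number from compound 1 to compound 2 (0.66 log units; beyond the scatter), beyond the scatter, and it comes with difluoromethyl in place of hydrogen on an aromatic carbon.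

Compound 3 `O=C(N[C@@H](CCN1C[C@@H]2CN(C(=O)c3ccc(C(F)(F)F)nn3)C[C@@H]2C1)c1cccc(F)c1)C1CCOC1` has not yet been measured and differs from compound 2 as follows: 6-(trifluoromethyl)pyridazin-3-yl in place of 5-(difluoromethyl)pyridin-2-yl on a carbonyl carbon. Among the measured compounds shown here, no measured compound carries the entering group, so the single measured step bears on this change only loosely. That step still sets the scale, so a step of no greater size is expected, and a move part of the way back toward compound 1 (55 mL.min-1.g-1) is the working guess. A lower number is expected, with the estimated change being a 2.1-fold lower number from compound 2 to compound 3 (0.32 log units; beyond the scatter), though the direction is uncertain. Compound 3 is estimated at 120 mL.min-1.g-1 (expected range 50 mL.min-1.g-1 to 280 mL.min-1.g-1).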

Compound 3, intrinsic clearance in microsomes: 263 mL.min-1.g-1
Compound 3: the middle estimate sits 2.2-fold (0.34 log units) below what was measured, within the range that was stated.
By their numbers in this assay, from the lowest: compound 1; then compounds 2 and 3 (each within the scatter of the next).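

In this assay, 6-(trifluoromethyl)pyridazin-3-yl in place of 5-(difluoromethyl)pyridin-2-yl on the carbonyl carbon gives a 1.0-fold higher number from compound 2 to compound 3 (0.02 log units; within the scatter) and so leaves the read-out within the scatter, even though both the ring and its fluorinated group differ. Set against the plain pyridin-2-yl, the same group gives a 4.8-fold higher number from compound 1 to compound 3 (0.68 log units; beyond the scatter) and thus repeats the step beyond the scatter seen with the difluoromethyl group, so at this place two different fluoroalkyl-bearing rings now stand apart from the unsubstituted ring of compound 1, and no compound shown goes against that. Nothing measured here accounts for this outcome.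

The ring and the fluorinated group change together from compound 2 to compound 3, so the share of each remains unresolved, and a pyridazin-3-yl without any fluorinated group would be needed to separate them. Also open, going by these compounds, is whether a ring carrying a nitrile, a methoxy group or an amine at this place would read with compound 1 or with compound 2 and compound 3.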